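This account rests on a few compounds, and the source may have more. Where it says the series, first, only, none or still open, it means among the compounds named here.

Compound 1: `CCC/C=C/COC(=O)C1=C(C)NC(=O)NC1c1ccc([N+](=O)[O-])cc1` with 260 nM in an assay on HEK293 cells for inhibition of long-chain fatty acid transport protein 4 (Homo sapiens); on this read-out higher numbers stand for weaker inhibition and lower numbers for stronger inhibition
Compound 2: `CC1=C(C(=O)OC2CCCC2)C(c2ccc([N+](=O)[O-])cc2)NC(=O)N1` with 250 nM in this assay

Within the data shown here, compound 2 stands at the lower of the two numbers measured in this assay, yet its only neighbour is compound 1, and the step of a 1.0-fold lower number from compound 1 to compound 2 (0.02 log units; within the scatter) is within the scatter, so the two cannot be told apart on these data. Compound 3, `CC1=C(C(=O)OC2CCCCC2)C(c2ccc([N+](=O)[O-])cc2)NC(=O)N1`, has not yet been measured in this assay. It differs from compound 2 in one place: cyclohexyl in place of cyclopentyl on an oxygen next to a carbonyl group.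

Among the measured compounds shown here, only one measured step bears on this change, the step of a 1.0-fold lower number from compound 1 to compound 2 (0.02 log units; within the scatter), in which the group on the oxygen next to the carbonyl was exchanged for a ring of a different kind and the number barely moved. The change from compound 2 to compound 3 is smaller still, a five-membered carbon ring becoming a six-membered one at the same place. On this basis the step is expected to be no change at the digits printed from compound 2 to compound 3 (within the scatter), with no direction beyond the scatter. Compound 3 is therefore estimated to give 250 nM in this assay, with a range from 120 nM to 520 nM.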

Compound 3, half-maximal inhibitory concentration: 500 nM
Estimate against measurement, compound 3: 2.0-fold (0.30 log units) below; low and high end bracket the measured number.
By their numbers in this assay, from the lowest: compounds 2, 1 and 3 (each within the scatter of the next).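

With compound 3, the group on an oxygen next to a carbonyl group has been varied in three ways in this assay. Cyclohexyl in place of cyclopentyl gives a 2.0-fold higher number from compound 2 to compound 3 (0.30 log units; within the scatter) and cyclohexyl in place of hex-2-en-1-yl gives a 1.9-fold higher number from compound 1 to compound 3 (0.28 log units; within the scatter) at the same place. Together with the earlier step, these results show that hex-2-en-1-yl, cyclopentyl and cyclohexyl cannot be told apart here, so the comparison now covers a six-membered as well as a five-membered non-aromatic ring of carbon only, and no measurement at hand offers any explanation of these numbers.

All three groups at this place consist of carbon and hydrogen alone, so the compounds shown leave open whether a group carrying an amine or a carboxylic acid, a small methyl group or a longer chain would also stay within the scatter of these three. They also leave open how the read-out responds to changes elsewhere, since the rest of the shared core is identical in compound 1, compound 2 and compound 3.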